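This account rests on a few compounds, and the source may have more. Where it says the series, first, only, none or still open, it means among the compounds named here.

Compound 3 `Nc1ccccc1NC(=O)c1ccc(Cn2cnc3c(Nc4cccc(Cl)c4)nc(Cl)nc32)cc1` is measured in a functional assay on HCT-116 cells (Homo sapiens) for antiproliferative activity, read by CCK-8 assay, with a stated time of 72 h, tested at 8 uM (on this read-out higher numbers stand for a stronger effect at the one concentration tested and lower numbers for a weaker effect), where compound 3 gives 78.4%. Compound 2 `Nc1ccccc1NC(=O)c1ccc(Cn2cnc3c(NCc4ccccc4)nc(Cl)nc32)cc1` gives 78.4%, and compound 3 stands level with it at the digits shown, the two together being the lowest of the three numbers; compound 1 `Nc1ccccc1NC(=O)c1ccc(Cn2cnc3c(Nc4ccccc4)nc(Cl)nc32)cc1` gives 83.5%. The measured steps were small: a number 5.1 percentage points lower from compound 1 to compound 2 (within the scatter), a number 5.1 percentage points lower from compound 1 to compound 3 (within the scatter), and no change at the digits printed from compound 2 to compound 3 (within the scatter).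

Compound 4 `CN1CCN(c2nc(Cl)nc3c2ncn3Cc2ccc(C(=O)Nc3ccccc3N)cc2)CC1` differs from compound 3 at the same position: 4-methylpiperazin-1-yl in place of (3-chlorophenyl)amino on an aromatic carbon. Every measured change at this spot stayed within the scatter, but none exchanged an anilino group for 4-methylpiperazin-1-yl, so the bearing is weak. A slight fall is expected, a number 10.4 percentage points lower from compound 3 to compound 4 (beyond the scatter), with wide uncertainty. Compound 4 is estimated at 68%, between 40% and 88%.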

Compound 4, a percentage reported as inhibition, at one concentration (the size of the read-out at that concentration, not a potency): 72.8%
Compound 4: the middle estimate sits 4.8 percentage points below what was measured; measured number inside the range.
By their numbers in this assay, from the lowest: compounds 4, 2, 3 and 1 (each within the scatter of the next, the first and the last beyond it).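

With 4-methylpiperazin-1-yl, the group at this position has no aromatic ring and no hydrogen-bond donor, yet the steps stay small against two neighbours: a number 5.6 percentage points lower from compound 3 to compound 4 (within the scatter) and a number 5.6 percentage points lower from compound 2 to compound 4 (within the scatter). Only the comparison with the plain anilino group gives a modest step beyond the scatter, the first at this position: a number 10.7 percentage points lower from compound 1 to compound 4 (beyond the scatter). No measurement here explains that difference.

On these data alone, it remains open whether the gap comes from the piperazine ring or its methyl group. A morpholine or a dimethylamino group at this position would help separate these possibilities.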